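The source may hold more compounds than are shown below. What is called first, only, known or untested is meant among the compounds shown, and "the series" means these compounds.

Of the compounds shown here, three built on a shared core have been measured in an assay on HEK293 cells for inhibition of Steryl-sulfatase (Homo sapiens), tested at 1 uM; on this read-out higher numbers stand for a stronger effect at the one concentration tested and lower numbers for a weaker effect. Compound 1 `CN(C)CCN(CCN(C)C)c1cccc(C(=O)N2CCc3ccc(OS(N)(=O)=O)cc3C2)c1` gives 17.1%. Compound 2 `CCN(Cc1ccccc1)Cc1ccc(S(=O)(=O)N2CCc3ccc(OS(N)(=O)=O)cc3C2)cc1` gives 31%, and compound 3 `CCN(Cc1ccccc1)Cc1ccc(CN2CCc3ccc(OS(N)(=O)=O)cc3C2)cc1` gives 17%. Compound 1 thus stands second highest of the three: its number and that of compound 3 lie within the usual scatter of each other, while the number of compound 2 lies above it by more than the scatter. Compound 4 `CCCN(Cc1ccccc1)c1cccc(C(=O)N2CCc3ccc(OS(N)(=O)=O)cc3C2)c1` has not yet been measured. It differs from compound 1 in one place: benzyl(propyl)amino in place of bis(2-(dimethylamino)ethyl)amino on an aromatic carbon. Among the measured compounds shown here, no measured pair shows this change directly, so a modest shift in this assay in either direction, or none beyond the scatter, seems plausible. For compound 4 a value of 22% is expected, between 8% and 40%. This amounts to an expected step of a number 4.9 percentage points higher from compound 1 to compound 4 (within the scatter), close to the scatter.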

Compound 4, a percentage reported as inhibition, at one concentration (the size of the read-out at that concentration, not a potency): 67.4%
For compound 4 the middle estimate is 45.4 percentage points below the measured one, outside the stated range (above it).
By their numbers in this assay, from the lowest: compounds 3 and 1 (each within the scatter of the next); then compound 2; then compound 4.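

At this aromatic carbon, meta to a large group, the choice of substituent matters greatly in this assay: benzyl(propyl)amino in place of bis(2-(dimethylamino)ethyl)amino gives a number 50.3 percentage points higher from compound 1 to compound 4 (beyond the scatter) in this single change. Both groups have 11 heavy atoms, so that count alone does not set the number. Nothing measured here shows which part of the change is responsible. Still open, on these data alone, is whether the benzyl or the propyl arm carries the gain. A butyl chain in place of propyl, or cyclohexylmethyl in place of benzyl, would be one way to separate them.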